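Trading a methoxy for hydrogen in compound 1

The source may report more compounds than this note shows. Statements on the series, on what has been measured and on what is new or still open speak of the compounds shown alone.

In a functional assay on the whole organism (strain Kunming) with Mus musculus as the target, with a stated time of 0.5 h (a lower number here means that less compound is needed, a higher number that more compound is needed for the effect), compound 1 `COc1cc(OC)c(OC)cc1/C=C/COC(=O)/C=C/c1ccc(OC)c(OC)c1` gives 173 mg/kg and compound 2 `COc1cc(OC)c(OC)cc1/C=C/COC(=O)/C=C/c1cc(OC)c(OC)c(OC)c1` gives 204 mg/kg. Within the data shown here, these are the only two numbers so far, and they lie within the scatter of each other, so compound 1 has no clear lead over compound 2.

Compound 3 `COc1cccc(/C=C/C(=O)OC/C=C/c2cc(OC)c(OC)cc2OC)c1` has not yet been measured. Its structure departs from compound 1 by hydrogen in place of methoxy on an aromatic carbon. This is hydrogen in place of methoxy on an aromatic carbon, which turns 3,4-dimethoxyphenyl into 3-methoxyphenyl.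

Among the measured compounds shown here, only one measured step bears on this change, and it is the opposite kind of exchange, methoxy in place of hydrogen on an aromatic carbon: a 1.2-fold higher number from compound 1 to compound 2 (0.07 log units; within the scatter). For the measured compounds named here, a single step is thin evidence, and no measured compound yet shows a methoxy being removed. Even so, that step gives no reason to expect a shift beyond the scatter in either direction in this assay. The expected step is a 1.1-fold higher number from compound 1 to compound 3 (0.03 log units; within the scatter). Compound 3 is estimated at 185 mg/kg, with an expected range from 100 mg/kg to 340 mg/kg.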

Compound 3, dose for half-maximal effect: 247 mg/kg
The estimate for compound 3 lay 1.3-fold (0.13 log units) below the measured number; low and high end bracket the measured number.
By their numbers in this assay, from the lowest: compounds 1, 2 and 3 (each within the scatter of the next).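

With compound 3, the methoxy on the 3,4-dimethoxyphenyl group, ortho to a methoxy group and para to a large group, is exchanged for hydrogen, leaving 3-methoxyphenyl. In this assay, this exchange gives a 1.4-fold higher number from compound 1 to compound 3 (0.15 log units; within the scatter), so taking a methoxy away from this group, like adding one in a 1.2-fold higher number from compound 1 to compound 2 (0.07 log units; within the scatter), stays within the scatter. Among these three compounds, the methoxy exchanges on this aromatic ring therefore do not separate the numbers, and nothing measured here accounts for that result.

What the compounds shown leave open is whether any group other than methoxy or hydrogen at this place, such as a hydroxyl, a chlorine or an amine, would shift the number beyond the scatter in this assay. On these data alone, it also remains open whether the last methoxy of the 3-methoxyphenyl group can be exchanged for hydrogen with the same small effect, and whether the methoxy groups on the other aromatic ring of the shared core behave like this one.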